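This account rests on a few compounds, and the source may have more. Where it says the series, first, only, none or still open, it means among the compounds named here.

In a functional assay on HepG2 cells (Homo sapiens) for antiproliferative activity, read by CCK-8 assay, with a stated time of 72 h, tested at 2 uM (a higher number here means a stronger effect of the compound at the concentration tested, a lower number a weaker effect), two compounds have been measured. Compound 1 `Nc1ccccc1NC(=O)/C=C/c1ccc(Cn2cnc3c(NC4CCCCC4)nc(Cl)nc32)cc1` gives 3.83%, and compound 2 `Nc1ccccc1NC(=O)/C=C/c1ccc(COCNc2nc(Nc3ccccc3)c3ncn(C4CCCC4)c3n2)cc1` gives 2.93%. The two values lie within the usual scatter of each other, so compound 1 cannot be set apart from compound 2 on these numbers. Compound 3 `CC1CCN(c2nc(Cl)nc3c2ncn3Cc2ccc(/C=C/C(=O)Nc3ccccc3N)cc2)CC1` is not yet measured. It differs from compound 1 in one place: 4-methylpiperidin-1-yl in place of cyclohexylamino on an aromatic carbon. For the measured compounds named here, no measured pair shows a change of this kind, so its effect is unknown. Because compound 1 gives 3.83%, the expected step is a number 0.2 percentage points higher from compound 1 to compound 3 (within the scatter), none beyond the scatter. Compound 3 is expected to give 4%, within -6% to 14%.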

Compound 3, a percentage reported as inhibition, at one concentration (the size of the read-out at that concentration, not a potency): 8.73%
The estimate for compound 3 lay 4.7 percentage points below the measured number, within the range that was stated.
By their numbers in this assay, from the lowest: compounds 2, 1 and 3 (each within the scatter of the next).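

In this assay, for the compounds shown here, the first single-place change at this position, 4-methylpiperidin-1-yl in place of cyclohexylamino, gives a number 4.9 percentage points higher from compound 1 to compound 3 (within the scatter). On the shared core, the entering group has 0 hydrogen-bond donors against 1 for cyclohexylamino, yet the step stays within the scatter, so this pair shows no effect of the change that can be told from noise. No supporting measurement bears on this result. As far as these compounds go, whether morpholine or an open-chain dimethylamino group at this position would produce a step beyond the scatter remains open.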